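This account rests on a few compounds, and the source may have more. Where it says the series, first, only, none or still open, it means among the compounds named here.

Measured so far:
Compound 1 `Cc1cc2[nH]nc(N)c2c(=O)[nH]1`: 6%
Compound 2 `Cc1cc2[nH]nc(N)c2c(N2CCCCC2)n1`: 46%
Compound 3 `Cc1cc2c(c(N)nn2C)c(=O)[nH]1`: 2%

All three were tested in an assay on isolated protein for inhibition of ribosomal protein S6 kinase alpha-1 (Homo sapiens), read by mobility shift assay, tested at 30 uM; on this read-out lower numbers stand for less inhibition and higher numbers for more inhibition at the one concentration tested (going by the name of the read-out). The change from compound 1 to compound 3, (methyl in place of hydrogen on an aromatic nitrogen), gave a step of a number 4 percentage points lower from compound 1 to compound 3 (within the scatter), so the two values are read as alike. Compound 2 stands highest of the three; its value and that of compound 1 lie beyond the scatter apart, yet the difference between the two cores is not broken down here. Compound 4 `Cc1cc2c(c(N)nn2C)c(N2CCCCC2)n1` differs from compound 2 by methyl in place of hydrogen on an aromatic nitrogen, the same change as between compound 1 and compound 3. On that one earlier step, the expected step from compound 2 to compound 4 in this assay is a number 8 percentage points lower from compound 2 to compound 4 (within the scatter), resting on a number 4 percentage points lower from compound 1 to compound 3 (within the scatter). Compound 4 is thus estimated at 38%, expected between 15% and 58%.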

Compound 4, a percentage reported as inhibition, at one concentration (the size of the read-out at that concentration, not a potency): 23%
Beside the measured number, compound 4's estimate is 15 percentage points above it; low and high end bracket the measured number.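

In this assay, methyl in place of hydrogen on an aromatic nitrogen gave a number 23 percentage points lower from compound 2 to compound 4 (beyond the scatter), so on this core the change lowers the reading. The step did not carry over at one size between the two cores: the same change on two cores in this assay, a number 4 percentage points lower (within the scatter) from compound 1 to compound 3 and a number 23 percentage points lower (beyond the scatter) from compound 2 to compound 4, 19 percentage points apart, beyond the scatter of two such steps. These two pairs show that the size of the step can depend on the core, but they do not show which difference between the cores accounts for this, or how the change would behave on a third core.

The compounds shown leave open how an ethyl group or a longer chain on that aromatic nitrogen would read in this assay. They also leave open whether a larger step would appear with a carboxylic acid elsewhere on the core.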